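Swapping a benzyl-type arm for a naphthalene arm

The source may report more compounds than this note shows. Statements on the series, on what has been measured and on what is new or still open speak of the compounds shown alone.

Measured so far:
compound 1, `Cc1cc(-c2ccccc2)n(/C(N)=N/S(=O)(=O)c2cc(C)c(Cl)cc2SCc2cccc3ccccc23)n1`, 7000 nM
compound 2, `Cc1cc(S(=O)(=O)/N=C(\N)n2nccc2-c2ccccc2)c(SCc2ccc(C(F)(F)F)cc2)cc1Cl`, 14000 nM

In a functional assay on HCT-116 cells (Homo sapiens) for cytotoxicity, read by MTT assay, with a stated time of 72 h (on this read-out lower numbers stand for stronger inhibition and higher numbers for weaker inhibition), compound 2 gives the higher of the two numbers, and compound 1 sits close to it: the gap between them is within the usual scatter, so no order between the two can be claimed. Compound 3, `Cc1cc(S(=O)(=O)/N=C(\N)n2nccc2-c2ccccc2)c(SCc2cccc3ccccc23)cc1Cl`, has not yet been measured. It differs from compound 2 in one place: naphthalen-1-yl in place of 4-(trifluoromethyl)phenyl on a saturated chain carbon bound to a sulfur. Among the compounds with values here, compound 1 also carries a ((naphthalen-1-yl)methyl)sulfanyl group, though on a differently substituted core, and no direct step to it exists.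

For compound 3 a step no larger than the scatter is expected, a 1.8-fold lower number from compound 2 to compound 3 (0.24 log units; within the scatter), leaning slightly toward a lower number because compound 1 with the same ((naphthalen-1-yl)methyl)sulfanyl group gives 7000 nM. The estimate for compound 3 in this assay is 8000 nM, with a plausible range from 3000 nM to 25000 nM.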

Compound 3, half-maximal inhibitory concentration: 7000 nM
Compound 3: the middle estimate sits 1.1-fold (0.06 log units) above what was measured; the measured number falls inside the stated range.
By their numbers in this assay, from the lowest: compounds 1, 3 and 2 (each within the scatter of the next).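

In this assay naphthalen-1-yl in place of 4-(trifluoromethyl)phenyl on a saturated chain carbon bound to a sulfur gives a 2.0-fold lower number from compound 2 to compound 3 (0.30 log units; within the scatter) and so, at this position, neither group can be ranked above the other. Hydrogen in place of methyl on an aromatic carbon gives no change at the digits printed from compound 1 to compound 3 (within the scatter) and so this methyl shows no measurable effect on the number in these cells. Nothing available explains either result.

Going by these compounds, both steps swap one carbon-based group for a closely related one, so it remains open whether a different kind of group would move the number beyond the scatter. An amine or a carboxylic acid on the aromatic ring of this arm, or a longer chain between the sulfur and that ring, could test this.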